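This account rests on a few compounds, and the source may have more. Where it says the series, first, only, none or still open, it means among the compounds named here.

Measured compounds in a functional assay on A549 cells (Homo sapiens) for inhibition, read by MTT assay, with a stated time of 48 h; a lower number here means a stronger inhibitor, a higher number a weaker inhibitor:
Compound 1 `COc1ccc2c(=O)c(/C=C/C(=O)Nc3ccccc3)coc2c1` gives 51000 nM.
Compound 2 `Cc1ccccc1NC(=O)/C=C/c1coc2cc(O)ccc2c1=O` gives > 100000 nM, which is a limit of the assay and not a number.
Compound 3 `O=C(/C=C/c1coc2cc(O)ccc2c1=O)NCc1ccccc1` gives > 100000 nM, again a limit of the assay and not a number.

Among the measured compounds shown here, compound 1 therefore holds the only read number in the set; the other two values sit at the limit of > 100000 nM in this assay, at which 2 of the 3 values shown sit. For the measured compounds named here, the one single-point step, a step that the two limits leave unreadable from compound 2 to compound 3, cannot be read, since both ends are limits.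

Compound 4 `COc1ccc(NC(=O)/C=C/c2coc3cc(OC)ccc3c2=O)cc1` differs from compound 1 by methoxy in place of hydrogen on an aromatic carbon. Going by the values given here, no measured step involves this change, so nothing in the set speaks for a shift in either direction. The step from compound 1 to compound 4 is thus expected to be a 1.0-fold lower number from compound 1 to compound 4 (0.01 log units; within the scatter), within the scatter. Compound 4 is estimated at 50000 nM, in the range 15000 nM to 150000 nM.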

Compound 4, half-maximal inhibitory concentration: 23000 nM
For compound 4 the middle estimate is 2.2-fold (0.34 log units) above the measured one, and the stated range covers the measured number.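

In this assay, among the compounds shown here, going from phenyl to 4-methoxyphenyl, para to a large group, gives a 2.2-fold lower number from compound 1 to compound 4 (0.35 log units; beyond the scatter) as the first step with both ends read. This aromatic carbon therefore accepts methoxy in place of hydrogen with the number moving to the stronger side, though this single change establishes no trend. Nothing in the data shown bears on the cause of this step.

From the compounds shown here alone, it remains open whether chlorine, an amine or a carboxylic acid at the same place would move the number in the same direction. Also open, going by these compounds, is whether ethoxy, a longer chain, would preserve this step.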